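Pyrrolidin-1-yl in place of (4-ethylphenyl)amino

The compounds below may be only part of what the source reports. "The series", "measured", "known", "first", "only" and "open" are said of these compounds alone.

Measured in a functional assay on HeLa cells (Homo sapiens) for inhibition, read by sulforhodamine B assay; on this read-out lower numbers stand for stronger inhibition and higher numbers for weaker inhibition:
- compound 1 `O=C1C(Nc2ccc(Br)cc2)=CC(=O)c2c1nc1n2[C@H]2OC[C@@H](O)[C@H]2OC1`: 5220 nM
- compound 2 `CCc1ccc(NC2=CC(=O)c3c(nc4n3[C@H]3OC[C@@H](O)[C@H]3OC4)C2=O)cc1`: 6510 nM
- compound 3 `CCc1ccc(NC2=CC(=O)c3nc4n(c3C2=O)[C@H]2OC[C@@H](O)[C@H]2OC4)cc1`: 3990 nM

Compound 2 lies within the usual scatter of both compound 1 and compound 3, so these three numbers cannot be ranked and form a single level of activity. The next compound to consider is compound 4 `O=C1C(N2CCCC2)=CC(=O)c2c1nc1n2[C@H]2OC[C@@H](O)[C@H]2OC1`, which has not yet been measured in this assay. Going there from compound 2 is a large change to the shared core: pyrrolidin-1-yl in place of (4-ethylphenyl)amino on a double-bonded ring carbon. In words, pyrrolidin-1-yl stands in place of (4-ethylphenyl)amino on a double-bonded ring carbon.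

Within the data shown here, only one measured step offers any guidance, and it does so indirectly. That step, a 1.2-fold higher number from compound 1 to compound 2 (0.10 log units; within the scatter), puts ethyl in place of bromo on an aromatic carbon. Among the measured compounds shown here, it keeps the aromatic ring, whereas the new change removes it, so no measurement yet shows what replacing the whole group does. With so little evidence, no clear move in either direction is expected, and the expected step is a 1.1-fold higher number from compound 2 to compound 4 (0.03 log units; within the scatter). For compound 4 the estimated value is 7000 nM, with an expected range from 2500 nM to 20000 nM.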

Compound 4, half-maximal inhibitory concentration: > 16000 nM
Compound 4 ended at the assay's limit; the forecaster's own chance of this, stated with the estimate: 8%; middle value at least 2.2-fold (0.35 log units) from the limit.
By their numbers in this assay, from the lowest: compounds 3, 1 and 2 (each within the scatter of the next). At a limit, above all of these: compound 4.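

In this assay, compounds 1 and 2 differ only in a substituent on the aromatic ring and stay within the scatter of each other, so they say nothing about how much the whole group at this position matters. Replacing that whole group with pyrrolidin-1-yl does matter, giving an at least 2.4-fold higher number from compound 2 to compound 4 (0.39 log units; beyond the scatter) and an at least 3.0-fold higher number from compound 1 to compound 4 (0.48 log units; beyond the scatter), and since a higher number means weaker inhibition, both steps show inhibition being lost. The reading for compound 4 is a limit of the assay and not an exact number, so these steps give only the smallest possible size of the loss: the limit of > 16000 nM in this assay, at which 1 of the 4 values shown sits.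

This single change removes the aromatic ring and the hydrogen-bond donor together and also makes the group smaller, so the compounds shown cannot tell which of these differences counts. A cyclohexylamino group would keep the nitrogen-bound hydrogen without the aromatic ring, and an N-methyl-N-phenylamino group would keep the aromatic ring without that hydrogen, so either could begin to separate the two.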